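The compounds below may be only part of what the source reports. "The series", "measured", "known", "first", "only" and "open" are said of these compounds alone.

Compound 1 `CC1(Cc2ccccc2)CC(S(=O)(=O)c2ccc(F)cc2)=C(c2ccc(/C(N)=N/O)cc2)O1` gives 102000 nM in an ADME assay on cells (Peritoneal macrophage, Mus musculus, strain Balb/c) for cytotoxicity, read by resazurin assay, with a stated time of 72 h (a higher number here means that more compound is tolerated, a lower number that less compound is tolerated), the highest of the three measured numbers. Compound 2 `CC1(Cc2cccc(/C(N)=N/O)c2)CC(S(=O)(=O)c2ccc(F)cc2)=C(c2ccc(/C(N)=N/O)cc2)O1` gives 50200 nM and compound 3 `CC1(Cc2cccc(C(F)(F)F)c2)CC(S(=O)(=O)c2ccc(F)cc2)=C(c2ccc(/C(N)=N/O)cc2)O1` gives 49800 nM in this assay. Both changes made so far on the benzyl ring lowered the number: a 2.0-fold lower number from compound 1 to compound 2 (0.31 log units; beyond the scatter) and a 2.0-fold lower number from compound 1 to compound 3 (0.31 log units; beyond the scatter); the values of compound 2 and compound 3 lie within the scatter of each other. Compound 4 `COc1ccc(CC2(C)CC(S(=O)(=O)c3ccc(F)cc3)=C(c3ccc(/C(N)=N/O)cc3)O2)cc1` differs from compound 1 by methoxy in place of hydrogen on an aromatic carbon, on an aromatic carbon of a six-membered aromatic ring of carbon only, para to a large group. The two measured steps on this ring are modest and point downward, so a similar or smaller drop is expected for compound 4: a 1.5-fold lower number from compound 1 to compound 4 (0.16 log units; within the scatter). Compound 4 is estimated at 70000 nM, with a range from 35000 nM to 140000 nM.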

Compound 4, half-maximal cytotoxic concentration: > 100000 nM
Compound 4 was reported as a limit; the forecaster's own chance of this, stated with the estimate: 20%; at least 1.4-fold (0.15 log units) between middle value and limit.
By their numbers in this assay, from the lowest: compounds 3 and 2 (each within the scatter of the next); then compound 1.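

Compound 4 stands only as a limit in this assay: the limit of > 100000 nM in this assay, at which 1 of the 4 values shown sits. Methoxy, para to a large group, therefore does not show the readable drop seen with the two earlier changes on this ring, though the step from compound 1 to compound 4 cannot be read. The limit gives only floors against the other two substituted compounds, an at least 2.0-fold higher number from compound 3 to compound 4 (0.30 log units; that floor lies within the scatter) and an at least 1.9-fold higher number from compound 2 to compound 4 (0.29 log units; that floor lies within the scatter).

On these data alone, the true value of compound 4 stays open. Also open, as far as these compounds go, is whether an amine or a carboxylic acid at the same place, para to a large group, would give a number as high.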